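Reshaping the amide chain beside a diarylurea core

The source may report more compounds than this note shows. Statements on the series, on what has been measured and on what is new or still open speak of the compounds shown alone.

Compound 1 `CNC(=O)C#Cc1ccc(NC(=O)Nc2ccc(Cl)c(C(F)(F)F)c2)cc1` gives in a functional assay on KETR3 cells (Homo sapiens) for inhibition, read by MTT assay, with a stated time of 120 h (on this read-out higher numbers stand for weaker inhibition and lower numbers for stronger inhibition), 24700 nM.
Compound 2 `CC(NC(=O)c1cccc(-c2ccc(NC(=O)Nc3ccc(Cl)c(C(F)(F)F)c3)cc2)c1)c1ccccc1` gives in this assay 6460 nM.
Compound 3 `CNC(=O)/C=C(\C)c1ccc(NC(=O)Nc2ccc(Cl)c(C(F)(F)F)c2)cc1` gives in this assay only a limit, > 50000 nM, not a number.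

Compound 3 therefore stands at the weak end of what has been measured, at the limit of > 50000 nM in this assay, at which 1 of the 3 values shown sits. Within the data shown here, the one measured step that touches it, an at least 2.0-fold higher number from compound 1 to compound 3 (0.30 log units; that floor lies within the scatter), shows the methyl-bearing ethenyl chain costing inhibition, though its floor lies within the scatter. Compound 4 `O=C(/C=C/c1ccc(NC(=O)Nc2ccc(Cl)c(C(F)(F)F)c2)cc1)NC1CCC1` reworks that same chain: 2-(cyclobutylcarbamoyl)ethenyl in place of 1-methyl-2-(methylcarbamoyl)ethenyl on an aromatic carbon. Among the measured compounds shown here, no measured step covers this exact exchange, so the expectation leans on compound 3 sitting at a limit. Compound 4 is expected near 20000 nM, between 5000 nM and 60000 nM. That estimate means an expected step of an at least 2.5-fold lower number from compound 3 to compound 4 (0.39 log units; beyond the scatter).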

Compound 4, half-maximal inhibitory concentration: 17300 nM
For compound 4 the middle estimate is 1.2-fold (0.06 log units) above the measured one; the range from low to high includes it.
By their numbers in this assay, from the lowest: compound 2; then compounds 4 and 1 (each within the scatter of the next). At a limit, above all of these: compound 3.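

Compound 3 gives only a limit, not a number: (the limit of > 50000 nM in this assay, at which 1 of the 4 values shown sits). Placing 2-(cyclobutylcarbamoyl)ethenyl at this position brings back a measurable value, with an at least 2.8-fold lower number from compound 3 to compound 4 (0.46 log units; beyond the scatter) as a floor on the true size of the change. This chain and 2-(methylcarbamoyl)ethynyl cannot be told apart, since a 1.4-fold lower number from compound 1 to compound 4 (0.15 log units; within the scatter) is no real difference.

On these data alone, the exchange from compound 3 removes the methyl on the chain and replaces the methyl on the amide together, so the share of each stays unknown. As far as these compounds go, how a carboxylic acid in place of the amide, or a longer chain on its nitrogen, would fare remains open.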